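The compounds below may be only part of what the source reports. "The series", "measured", "known", "first", "only" and "open" are said of these compounds alone.

Of the compounds shown here, three have been measured in a functional assay on CHO cells for agonist activity at Free fatty acid receptor 1 (Homo sapiens), read by FLIPR and calcium flux, in the presence of a further agent that is not named here; on this read-out higher numbers stand for an effect only at larger amounts of compound and lower numbers for an effect already at smaller amounts. Compound 1 `O=C(O)CCc1ccc(OCc2noc(-c3ccccc3)n2)cc1` gives 2650 nM, compound 3 `COc1cccc(-c2noc(COc3ccc(CCC(=O)O)cc3Cl)n2)c1` gives 3000 nM, and compound 2 `O=C(O)CCc1ccc(OCc2nc(-c3ccccc3Cl)no2)cc1` gives 1200 nM. Compound 2 therefore stands lowest of the three, with compound 1 nearest and compound 3 furthest, both gaps lying beyond the scatter. Compound 4 `CCc1ccc(-c2noc(COc3ccc(CCC(=O)O)cc3)n2)cc1` is not yet measured; it differs from compound 2 in one place: 4-ethylphenyl in place of 2-chlorophenyl on an aromatic carbon. For the measured compounds named here, since the three measured compounds differ from one another in more than one place, no single step among them guides this change. The step from compound 2 to compound 4 in this assay is expected to be a modest rise, a 1.7-fold higher number from compound 2 to compound 4 (0.22 log units; within the scatter), with a loss beyond the scatter judged somewhat more likely than a gain. Compound 4 is therefore estimated at 2000 nM, within a range from 800 nM to 5000 nM.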

Compound 4, half-maximal effective concentration: 210 nM
Beside the measured number, compound 4's estimate is 9.5-fold (0.98 log units) above it; the whole stated range lies above it.
By their numbers in this assay, from the lowest: compound 4; then compound 2; then compounds 1 and 3 (each within the scatter of the next).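

In this assay, for the compounds shown here, the position between two ring nitrogen atoms proves highly responsive to the phenyl group it carries: 4-ethylphenyl in place of 2-chlorophenyl gives a 5.7-fold lower number from compound 2 to compound 4 (0.76 log units; beyond the scatter) and is the first single change read at this position. The phenyl ring itself stays, so the step comes with a change of substituent and of where it sits on that ring. Nothing at hand gives a cause for this step.

The compounds shown leave open whether the ethyl group or its place carries the step, as a 4-chlorophenyl group could tell. As far as these compounds go, how a longer chain, such as 4-butylphenyl, would read here also remains open.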